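The compounds below may be only part of what the source reports. "The series", "measured", "known", "first", "only" and "open" are said of these compounds alone.

Values so far in a functional assay on HCT-8 cells (Homo sapiens) for cytotoxicity; on this read-out higher numbers stand for an effect only at larger amounts of compound and lower numbers for an effect already at smaller amounts:
- compound 1 `CC(C)Oc1cc(-c2ccccc2)nc2ccccc12` gives 10 ug/mL
- compound 2 `Oc1cc(-c2ccccc2)nc2cc(F)ccc12` gives 3.45 ug/mL

Compound 1, at 10 ug/mL, holds the higher of the two numbers, and the gap to compound 2 lies beyond the scatter. Going by the values given here, no measured pair differs in one place only, so no measured step guides the next change. Compound 3 `CC(C)COc1cc(-c2ccccc2)nc2ccccc12` differs from compound 1 by isobutyl in place of isopropyl on an oxygen on an aromatic ring. The estimated step of no change at the digits printed from compound 1 to compound 3 (within the scatter) is expected to stay within the scatter in this assay, with no direction expected. For compound 3 the estimated value is 10 ug/mL, with an expected range from 3.5 ug/mL to 30 ug/mL in this read-out.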

Compound 3, half-maximal effective concentration: > 10 ug/mL
Compound 3: only a limit was reported; the forecaster's own chance of this, stated with the estimate: 25%; the middle value lies on the limit itself.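

In this assay, isobutyl in place of isopropyl on this oxygen gives a number no lower from compound 1 to compound 3 (the limit leaves the size open), so this change brings no readable gain on this read-out. For compound 3, > 10 ug/mL is a limit of the assay and not a number. The step therefore has a direction but no size: the limit of > 10 ug/mL in this assay, at which 1 of the 3 values shown sits.

Still open, going by these compounds, is how far the number for compound 3 would lie from that of compound 1. Also open, on these data alone, is whether a longer chain on this oxygen, ending in an amine or a carboxylic acid, would shift the value in this assay.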